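A few compounds are considered here, and "the series" means these few. Any claim that something is new, unique, unknown or untested is made for them only; others in the source may bear on it.

Compound 2 `O=C(CO[N+](=O)[O-])Nc1ccc(C(=O)/C=C/c2ccc(Cl)cc2)cc1` and compound 1 `COc1ccc(/C=C/C(=O)c2ccc(NC(=O)CBr)cc2)cc1` are the two compounds with measurements here. In a functional assay on the whole organism (strain albino) for inhibition, with Rattus norvegicus as the target, read by paw edema, with stated times of 30 min and 1 h, at a dose of 100 mg/kg by the oral route (on this read-out lower numbers stand for less inhibition and higher numbers for more inhibition at the one dose given (going by the name of the read-out)), compound 2 gives 42%, and in this assay compound 1 gives 37%; the gap between the two readings lies within the usual scatter, so the pair shows no separation. Compound 3 `COc1ccc(/C=C/C(=O)c2ccc(NC(=O)CO[N+](=O)[O-])cc2)cc1` has not yet been measured. Compound 3 differs from compound 2 by methoxy in place of chloro on an aromatic carbon. Among the measured compounds shown here, since no step between measured compounds isolates this change, the only guide is that compound 1, which carries the methoxy group, and compound 2, which carries the chloro group, read within the scatter of each other. On that basis the step from compound 2 to compound 3 in this assay is expected to be small, about a number 2 percentage points lower from compound 2 to compound 3 (within the scatter), and not beyond the scatter in either direction. Compound 3 is therefore estimated to give 40% in this assay, with a range from 25% to 55%.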

Compound 3, a percentage reported as inhibition, in the whole organism at one dose (the size of the read-out at that dose, not a potency): 33%
Compound 3: middle estimate off by 7 percentage points, on the high side; low and high end bracket the measured number.
By their numbers in this assay, from the lowest: compounds 3, 1 and 2 (each within the scatter of the next).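

Among the compounds shown here, with compound 3, the change from 4-chlorophenyl to 4-methoxyphenyl can be read on its own for the first time: in this assay, with the nitrooxy chain held constant, the step is a number 9 percentage points lower from compound 2 to compound 3 (within the scatter). The chain can also now be read separately, since nitrooxy in place of bromo on the saturated chain carbon bound to a carbonyl carbon, with the methoxy group held constant, gives a number 4 percentage points lower from compound 1 to compound 3 (within the scatter). Neither single change therefore separates the compounds at this one dose, and no measurement here bears on the reason.

As far as these compounds go, it remains open whether an amine or a carboxylic acid on the aromatic carbon would move the reading beyond the scatter. A longer chain carrying the nitrooxy group is likewise an open case.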